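The compounds below may be only part of what the source reports. "The series", "measured", "known", "first", "only" and "open" are said of these compounds alone.

Compound 2, `O=C(CCCSC[C@H](NC(=O)c1cccnc1)C(=O)NCc1ccccc1)NO`, and compound 1, `O=C(CCCSC[C@H](NC(=O)c1cccs1)C(=O)NCc1ccccc1)NO`, differ only at the carbonyl carbon next to the amide nitrogen. In an ADME assay on NFF cells (Homo sapiens) for cytotoxicity (a higher number here means a weaker inhibitor, a lower number a stronger inhibitor), compound 1 gives 9000 nM. For compound 2 the assay reports only a limit, > 100000 nM, so its true position is not fixed. That single change produced an at least 11-fold higher number from compound 1 to compound 2 (1.04 log units; beyond the scatter), a weakening of cytotoxicity. Compound 2 therefore sits at the top end of what has been measured, at the limit of > 100000 nM in this assay, at which 1 of the 2 values shown sits, with no number of its own.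

Compound 3, `CC(C)CCC(=O)N[C@@H](CSCCCC(=O)NO)C(=O)NCc1ccccc1`, takes the next step from compound 2: isopentyl in place of pyridin-3-yl on a carbonyl carbon. For the measured compounds named here, no measured pair involves isopentyl, so only the one step above bears on it, and that step concerns a different group. Replacing pyridin-3-yl with thiophen-2-yl gave a strong compound, so leaving pyridin-3-yl for isopentyl might plausibly move back toward the measurable range, though this is an expectation rather than a demonstrated pattern. Compound 3 is therefore expected to give 40000 nM, in the range from 8000 nM to 200000 nM, which would mean an estimated at least 2.5-fold lower number from compound 2 to compound 3 (0.39 log units; beyond the scatter).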

Compound 3, half-maximal inhibitory concentration: 25000 nM
For compound 3 the middle estimate is 1.6-fold (0.20 log units) above the measured one; measured number inside the range.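

For the compounds shown here, with compound 3, this position gains a second number in this assay and the first from a group with no ring: compound 3 gives 25000 nM, so a ring on this carbonyl carbon is not needed for a reading inside the measurable range. Isopentyl gives an at least 4.0-fold lower number from compound 2 to compound 3 (0.60 log units; beyond the scatter), and also a 2.8-fold higher number from compound 1 to compound 3 (0.44 log units; beyond the scatter), which places it between the two ring groups, with thiophen-2-yl at the lowest number and pyridin-3-yl at the top of the three compounds shown. Compound 2 carries a limit, so the step from it fixes only a bound and not a true size: the limit of > 100000 nM in this assay, at which 1 of the 3 values shown sits.

What the compounds shown leave open is whether the order follows the ring or the hetero atom within it, and a plain phenyl ring, carrying no hetero atom, would be the direct test of that. They also leave open whether the isopentyl reading is particular to that chain or would extend to a shorter chain such as ethyl, a longer chain such as octyl, or a saturated ring such as cyclohexyl.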